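The compounds below may be only part of what the source reports. "The series", "measured", "known", "first", "only" and "open" are said of these compounds alone.

Measured compounds in an assay on membranes from brain for displacement of a labelled ligand from Neuronal acetylcholine receptor; alpha4/beta2 (Rattus norvegicus), with a stated time of 3 h; on this read-out lower numbers stand for stronger inhibition and higher numbers for weaker inhibition:
- compound 1 `COc1cccc(/C=C2\CCCN=C2c2cccnc2)c1` gives 1180 nM
- compound 2 `CCN(CC)c1ccc(/C=C2\CCCN=C2c2cccnc2)c(O)c1` gives 130 nM
- compound 3 `CC(=O)c1ccc(/C=C2\CCCN=C2c2cccnc2)cc1` gives 4490 nM

Compound 3 stands at the highest number of the three in this assay, that is, the weakest inhibition shown here. Its nearest neighbour is compound 1, whose number lies beyond the scatter below it, and the furthest is compound 2, whose number lies far below it. Compound 4 `CC(C)(C)C(=O)Oc1ccc(/C=C2\CCCN=C2c2cccnc2)cc1` is the next compound of the series and has not yet been measured in this assay. It differs from compound 3 in one place: ((tert-butyl)carbonyl)oxy in place of acetyl on an aromatic carbon. Among the measured compounds shown here, no measured pair in the set shows this kind of exchange, so its effect can only be estimated. The two groups share a carbonyl; the new one is larger and is attached through an oxygen rather than directly. The expectation is a small step, close to the scatter, toward a lower number in this assay, estimated as a 1.8-fold lower number from compound 3 to compound 4 (0.25 log units; within the scatter). Compound 4 is therefore expected to give about 2500 nM in this assay, with a range from 800 nM to 8000 nM.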

Compound 4, inhibition constant: 830 nM
Compound 4: middle estimate off by 3.0-fold (0.48 log units), on the high side; low and high end bracket the measured number.
By their numbers in this assay, from the lowest: compound 2; then compounds 4 and 1 (each within the scatter of the next); then compound 3.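

Among the compounds shown here, compound 3 and compound 4 form the first pair in the set that differs in one place, so this is the first direct reading of the aromatic carbon para to a large group. In this assay, putting ((tert-butyl)carbonyl)oxy in place of acetyl gives a 5.4-fold lower number from compound 3 to compound 4 (0.73 log units; beyond the scatter), a modest step that lies beyond the scatter and shows that the read-out responds to the group at this position. Nothing available accounts for the size or direction of this step.

The exchange alters the size of the group and adds an oxygen link in one move, and the compounds shown do not separate these two changes. From the compounds shown here alone, how an amine or a carboxylic acid on the same carbon would read also remains open.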